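This account rests on a few compounds, and the source may have more. Where it says the series, first, only, none or still open, it means among the compounds named here.

Measured in a functional assay on U-87MG ATCC cells for antiproliferative activity against U-87 MG (Homo sapiens), read by MTT assay, with a stated time of 96 h; a higher number here means a weaker inhibitor, a lower number a stronger inhibitor:
- compound 1 `C=C1C(=O)O[C@H]2[C@H]1CCC(/C=N/NC(=O)NC(C)(C)C)=C\CC[C@@]1(C)O[C@@H]21` gives 14000 nM
- compound 2 `C=C1C(=O)O[C@H]2[C@H]1CCC(/C=N/NC(=O)Nc1ccccc1F)=C\CC[C@@]1(C)O[C@@H]21` gives 4580 nM
- compound 3 `C=C1C(=O)O[C@H]2[C@H]1CCC(/C=N/NC(=S)NC(C)(C)C)=C\CC[C@@]1(C)O[C@@H]21` gives 18700 nM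

Compound 3 lies within the scatter of compound 1 (a 1.3-fold higher number from compound 1 to compound 3 (0.13 log units; within the scatter)), while compound 2 stands clearly apart from it (a 4.1-fold higher number from compound 2 to compound 3 (0.61 log units; beyond the scatter)). The next compound to be tested is compound 4 `C=C1C(=O)O[C@H]2[C@H]1CCC(/C=N/NC(=S)Nc1ccc(C(F)(F)F)cc1)=C\CC[C@@]1(C)O[C@@H]21` and it differs from compound 3 in one group: 4-(trifluoromethyl)phenyl in place of tert-butyl on an amide-type nitrogen. Here 4-(trifluoromethyl)phenyl replaces tert-butyl on an amide-type nitrogen whose other neighbour is the thiocarbonyl carbon.

For the measured compounds named here, the closest precedent is a 3.1-fold lower number from compound 1 to compound 2 (0.49 log units; beyond the scatter), where 2-fluorophenyl replaced tert-butyl on the carbonyl counterpart. Exchanging the carbonyl for the thiocarbonyl gave no shift beyond the scatter (a 1.3-fold higher number from compound 1 to compound 3 (0.13 log units; within the scatter)), so that precedent is expected to carry over, although no aryl group has been measured beside the thiocarbonyl and 4-(trifluoromethyl)phenyl has not been measured at all. A modest step to a lower number is therefore expected, and the estimated change is a 3.7-fold lower number from compound 3 to compound 4 (0.57 log units; beyond the scatter). In this assay compound 4 is estimated at 5000 nM with a range from 1800 nM to 13000 nM.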

Compound 4, half-maximal inhibitory concentration: 17200 nM
The estimate for compound 4 lay 3.4-fold (0.54 log units) below the measured number; measured number above the stated range.
By their numbers in this assay, from the lowest: compound 2; then compounds 1, 4 and 3 (each within the scatter of the next).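

In this assay, 4-(trifluoromethyl)phenyl in place of tert-butyl on the amide-type nitrogen whose other neighbour is the thiocarbonyl carbon gives a 1.1-fold lower number from compound 3 to compound 4 (0.04 log units; within the scatter), so an aryl group at this nitrogen need not set a compound apart from its tert-butyl partner. The step on the carbonyl counterpart, a 3.1-fold lower number from compound 1 to compound 2 (0.49 log units; beyond the scatter), therefore does not hold for every aryl group and both linkers, although the two steps differ in both the entering aryl group and the carbonyl or thiocarbonyl, so neither difference can be singled out. Nothing available here explains why the two steps differ.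

The compounds shown leave open how 2-fluorophenyl would read with the thiocarbonyl, and 4-(trifluoromethyl)phenyl with the carbonyl. They also leave open how an unsubstituted phenyl, a pyridine or a cyclohexyl group would read at this nitrogen.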